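The source may hold more compounds than are shown below. What is called first, only, known or untested is meant among the compounds shown, and "the series" means these compounds.

Compound 1 `O=[N+]([O-])c1c(CS(=O)(=O)c2ccccc2)nc2c(-c3ccc(Cl)cc3)cc(Cl)cn12`: > 3900 nM
Compound 2 `N#Cc1ccc(-c2cc(Cl)cn3c([N+](=O)[O-])c(CS(=O)(=O)c4ccccc4)nc23)cc1`: > 3900 nM
Compound 3 `O=[N+]([O-])c1c(CS(=O)(=O)c2ccccc2)nc2c(-c3ccc(F)cc3)cc(Cl)cn12`: > 15600 nM

Each of these entries is a limit and not a number. In an ADME assay on HepG2 cells (Homo sapiens) for cytotoxicity, read by MTT assay, with a stated time of 72 h (a higher number here means that more compound is tolerated, a lower number that less compound is tolerated), compound 3 gives > 15600 nM, which is a limit. Compound 3 thus stands at the limit of > 15600 nM in this assay, at which 1 of the 3 values shown sits, while compound 1 and compound 2 stand at the limit of > 3900 nM in this assay, at which 2 of the 3 values shown sit.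

Compound 4 `O=[N+]([O-])c1c(CS(=O)(=O)c2ccccc2)nc2c(-c3ccncc3)cc(Cl)cn12` differs from compound 3 by pyridin-4-yl in place of 4-fluorophenyl on an aromatic carbon. The measured steps that bear on this change alter the same aryl group: a step that the two limits leave unreadable from compound 1 to compound 3 and a step that the two limits leave unreadable from compound 2 to compound 3. The third is a step that the two limits leave unreadable from compound 1 to compound 2. None has a readable size, so they give no guide to a direction in this assay, and no step beyond the usual scatter is expected. The expected step is a step that the limit leaves unreadable from compound 3 to compound 4. The estimate for compound 4 is 25000 nM, with an expected range from 10000 nM to 80000 nM.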

Compound 4, half-maximal cytotoxic concentration: > 50000 nM
Compound 4: a limit, no number (the forecaster's own chance of this, stated with the estimate: 75%); middle value at least 2.0-fold (0.30 log units) from the limit.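

In this assay compound 4 gives > 50000 nM, which is a limit. The steps to it from compound 1, compound 2 and compound 3 cannot be read. The compounds shown leave open whether pyridin-4-yl differs at all from 4-fluorophenyl, 4-chlorophenyl or 4-cyanophenyl in this read-out.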